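Three limits and a methoxy-for-methyl swap

The source may hold more compounds than are shown below. What is called first, only, known or untested is meant among the compounds shown, and "the series" means these compounds.

Compound 1 `Cc1ccc(-c2c(CNC(C)(C)C)c(C(=O)O)nn2-c2ccccc2)cc1` carries a methyl group on its outer ring; compound 2 `COc1ccc(-c2c(CNC(C)(C)C)c(C(=O)O)nn2-c2ccccc2)cc1` and compound 3 `Cc1ccc(-c2c(CNC(C)(C)C)c(C(=O)O)nn2-c2ccc(Cl)cc2)cc1` each alter one position of it. In a functional assay on 786-0 cells (Homo sapiens) for inhibition, read by sulforhodamine B assay, with a stated time of 48 h (on this read-out lower numbers stand for stronger inhibition of growth and higher numbers for weaker inhibition of growth), compound 1 reaches only a limit, > 688000 nM. In this assay compound 2 likewise gives only a limit, > 659000 nM. Compound 3 in this assay also stops at a limit, > 629000 nM.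

The change from compound 1 to compound 2 is methoxy in place of methyl on an aromatic carbon; its step is a step that the two limits leave unreadable from compound 1 to compound 2, both of its ends being limits. The change from compound 1 to compound 3 is chloro in place of hydrogen on an aromatic carbon; its step is a step that the two limits leave unreadable from compound 1 to compound 3. Compound 3 sits at the limit of > 629000 nM in this assay, at which 1 of the 3 values shown sits, compound 2 at the limit of > 659000 nM in this assay, at which 1 of the 3 values shown sits, and compound 1 at the limit of > 688000 nM in this assay, at which 1 of the 3 values shown sits; with every value a limit, no order among the three can be read.

Compound 4 `COc1ccc(-c2c(CNC(C)(C)C)c(C(=O)O)nn2-c2ccc(Cl)cc2)cc1` is not yet measured. Against compound 3 it shows (methoxy in place of methyl on an aromatic carbon), the same change as from compound 1 to compound 2, at a place described in the same words. Among the compounds with values here, that earlier step was unreadable, and the only guide is that compound 1, compound 2 and compound 3 all end at limits in this assay. The expected step is a step that the limit leaves unreadable from compound 3 to compound 4, resting on the unreadable earlier step that the two limits leave unreadable from compound 1 to compound 2 and on the limit of compound 3, > 629000 nM. Compound 4 is therefore estimated at about 700000 nM, between 450000 nM and 1500000 nM, most likely reported again as only a limit.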

Compound 4, concentration for 50% growth inhibition: > 605000 nM
Compound 4 ended at the assay's limit; the forecaster's own chance of this, stated with the estimate: 85%; the middle value does not contradict the limit.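

In this assay compound 4 gives only a limit, > 605000 nM. With limits at both ends, neither the step to compound 4 from compound 3 nor the step to compound 4 from compound 2 can be read. The four compounds shown leave open whether methoxy in place of methyl, or chloro in place of hydrogen, changes growth inhibition at all: none of them yields a number.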